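A few compounds are considered here, and "the series" means these few. Any claim that something is new, unique, unknown or untested is made for them only; others in the source may bear on it.

Measured compounds:

Compound 1, `C=C1CC[C@@H]2[C@](C)(COC(C)=O)[C@H](O)CC[C@@]2(C)[C@@H]1C/C=C1\C=COC1=O`, in an ADME assay on HepG2 2.2.15 cells (Homo sapiens) for cytotoxicity, read by MTT assay (on this read-out lower numbers stand for higher toxicity in this test and higher numbers for lower toxicity in this test), compound 1 gives 334000 nM.
Compound 2, `C=C1CC[C@@H]2[C@](C)(COC(=O)CCCC)[C@H](O)CC[C@@]2(C)[C@@H]1C/C=C1\C=COC1=O`, in this assay compound 2 gives 225000 nM.
Compound 3, `C=C1CC[C@@H]2[C@](C)(CO)[C@H](OC(C)=O)CC[C@@]2(C)[C@@H]1C/C=C1\C=COC1=O`, in this assay compound 3 gives 872000 nM.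

Compound 1 and compound 2 share one core, and the change between them is propyl in place of hydrogen on a saturated chain carbon bound to a carbonyl carbon. Its measured step is a 1.5-fold lower number from compound 1 to compound 2 (0.17 log units; within the scatter). Compound 3 carries the same atoms as compound 1 joined differently; the difference between the two cores is not broken down here. Compound 3 stands highest of the three numbers in this assay, and its gaps to compound 1 and to compound 2 both lie beyond the scatter.

Compound 4, `C=C1CC[C@@H]2[C@](C)(CO)[C@H](OC(=O)CCCC)CC[C@@]2(C)[C@@H]1C/C=C1\C=COC1=O`, has not yet been measured. The change from compound 3 to compound 4 is propyl in place of hydrogen on a saturated chain carbon bound to a carbonyl carbon, the same change as that from compound 1 to compound 2, made on the same kind of place. Since the step it gave from compound 1 to compound 2 was within the scatter, the expected step from compound 3 to compound 4 in this assay is likewise small, a 1.5-fold lower number from compound 3 to compound 4 (0.16 log units; within the scatter), because it rests on a 1.5-fold lower number from compound 1 to compound 2 (0.17 log units; within the scatter) alone. Going by the values given here, on that basis compound 4 is estimated at 600000 nM in this assay, with a range from 300000 nM to 1200000 nM that reflects the single supporting pair.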

Compound 4, half-maximal cytotoxic concentration: 126000 nM
Beside the measured number, compound 4's estimate is 4.8-fold (0.68 log units) above it, and the stated range ends above it.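

In this assay, the change of propyl in place of hydrogen on a saturated chain carbon bound to a carbonyl carbon, which here turns acetoxy into (butylcarbonyl)oxy, gives a 6.9-fold lower number from compound 3 to compound 4 (0.84 log units; beyond the scatter). Set beside the same change on the core of compound 1, the step did not carry over in size from one core to the other: the same change on two cores in this assay, a 1.5-fold lower number (0.17 log units; within the scatter) from compound 1 to compound 2 and a 6.9-fold lower number (0.84 log units; beyond the scatter) from compound 3 to compound 4, 4.7-fold (0.67 log units) apart, beyond the scatter of two such steps. Going by these compounds alone, this shows that, for these two pairs, the size of the step on one core was not a reliable guide to its size on the other, but with only one pair on each core it does not show why the two steps differ, nor how the change would behave on any further core.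

The compounds shown leave open whether a longer chain than butyl, or a branched chain such as tert-butyl, would follow the step seen on the core of compound 3 or the one seen on the core of compound 1. They also leave open whether an amide in place of the ester would keep the two cores apart in the same way.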